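The source may report more compounds than this note shows. Statements on the series, on what has been measured and on what is new or still open speak of the compounds shown alone.

Measured so far:
Compound 1 `N#Cc1ccc(Cc2cnc(CCc3ccc(-c4ccccc4C(=O)O)cc3)[nH]2)cc1` gives 723 nM in an in vitro functional assay on cells for agonist activity at Bombesin receptor subtype-3 (Mus musculus), read by luminescence and calcium flux; on this read-out higher numbers stand for an effect only at larger amounts of compound and lower numbers for an effect already at smaller amounts.
Compound 2 `CCCCc1cnc(C(C)Cc2ccc(-c3ccccc3C(=O)O)cc2)[nH]1` gives 184 nM in this assay.
Compound 3 `CCC(C)(C)Cc1c[nH]c(CCc2ccc(-c3ccccc3C(=O)O)cc2)n1` gives 9.6 nM in this assay.

Among these three, compound 1 stands at the highest number, and both other compounds sit beyond the scatter below it. The unmeasured compound 4 `O=C(O)c1ccccc1-c1ccc(CCc2ncc(CC3CC3)[nH]2)cc1` keeps the shared core of compound 1 and changes one group: cyclopropyl in place of 4-cyanophenyl on a saturated chain carbon bound to an aromatic carbon. Compound 2 and compound 3, which carry a saturated group rather than an aromatic one on the corresponding chain carbon, both give lower numbers than compound 1, with compound 3 giving 9.6 nM. On that basis, compound 4 is expected to move in the same direction. The step of a 12-fold lower number from compound 1 to compound 4 (1.08 log units; beyond the scatter) is estimated as a decrease beyond the scatter. Compound 4 is expected to give about 60 nM, in a range from 15 nM to 250 nM.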

Compound 4, half-maximal effective concentration: 72 nM
Compound 4: the middle estimate sits 1.2-fold (0.08 log units) below what was measured; low and high end bracket the measured number.
By their numbers in this assay, from the lowest: compound 3; then compound 4; then compound 2; then compound 1.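

In this assay, within the data shown here, putting cyclopropyl in place of 4-cyanophenyl on a saturated chain carbon bound to an aromatic carbon gives a 10-fold lower number from compound 1 to compound 4 (1.00 log units; beyond the scatter) and offers the first comparison here that differs in one place only. It shows that this place does not need the aromatic ring or the nitrile, and that a much smaller group can give the lower number. Nothing available explains the step.

The compounds shown leave open whether the nitrile or the whole ring matters, which plain phenyl could separate. On these data alone, how cyclobutyl or cyclohexyl would read here also remains open.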